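Corticotropin-releasing factor receptor 1 series: amine replacements on the core

A few compounds are considered here, and "the series" means these few. Any claim that something is new, unique, unknown or untested is made for them only; others in the source may bear on it.

Measured compounds in an assay on cells for displacement of a labelled ligand from corticotropin-releasing factor receptor 1 (Homo sapiens), with a stated time of 100 min; a higher number here means a weaker inhibitor, a lower number a stronger inhibitor:
compound 1 `Cc1cc(C)c(-n2c(Cl)cn3c(CN(CCC(F)(F)F)CC4CC4)c(C(F)(F)F)nc23)c(C)c1` — 16 nM
compound 2 `Cc1cc(C)c(-n2c(Cl)cn3c(CN(CCC(F)(F)F)Cc4cccc(F)c4)c(C(F)(F)F)nc23)c(C)c1` — 49 nM
compound 3 `Cc1cc(C)c(-n2c(Cl)cn3c(CN4CCCC4Cc4ccccc4)c(C(F)(F)F)nc23)c(C)c1` — 190 nM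

Compound 1 gives the lowest number of the three. Going by the values given here, the nearest is compound 2, reached by the step of a 3.1-fold higher number from compound 1 to compound 2 (0.49 log units; beyond the scatter); compound 3 stands furthest away, and no single-point step between compound 1 and compound 3 is recorded, so only the two values themselves can be compared.

Compound 4 `Cc1cc(C)c(-n2c(Cl)cn3c(CN4CCCC(C)C4)c(C(F)(F)F)nc23)c(C)c1` has not yet been measured in this assay. Against compound 1 the change is 3-methylpiperidin-1-yl in place of (cyclopropylmethyl)(3,3,3-trifluoropropyl)amino on a saturated chain carbon bound to an aromatic carbon.

Among the compounds with values here, only one measured step is available for guidance, and it does not match this change: it exchanges one arm of the amine for another, whereas here the whole amine substituent is exchanged for a ring-closed one with fewer heavy atoms and no fluorine. That step, a 3.1-fold higher number from compound 1 to compound 2 (0.49 log units; beyond the scatter), shows that altering the amine substituent can move the number beyond the scatter. The value of compound 3 shows that a different ring-closed amine on the same core gives a clearly higher number than compound 1. On this basis a weakening beyond the scatter is expected for compound 4, of size a 3.8-fold higher number from compound 1 to compound 4 (0.57 log units; beyond the scatter). Compound 4 is estimated at 60 nM, within 20 nM to 200 nM.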

Compound 4, inhibition constant: 5800 nM
Compound 4: the middle estimate sits 97-fold (1.99 log units) below what was measured, and the stated range ends below it.
By their numbers in this assay, from the lowest: compound 1; then compound 2; then compound 3; then compound 4.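

Notes on the amine at the saturated chain carbon bound to an aromatic carbon: in this assay, replacing the whole (cyclopropylmethyl)(3,3,3-trifluoropropyl)amino group with 3-methylpiperidin-1-yl gives a 360-fold higher number from compound 1 to compound 4 (2.56 log units; beyond the scatter). This step is much larger than a 3.1-fold higher number from compound 1 to compound 2 (0.49 log units; beyond the scatter), which exchanged only one arm of the amine, so the number at this place can move over a far wider range than the earlier pair showed. Ring closure alone does not set the level among the compounds shown: the ring-closed amine of compound 3 gives 190 nM, whereas the ring-closed amine of compound 4 gives 5800 nM. No measurement available here accounts for the size of this step.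

The step from compound 1 changes ring closure, the 3,3,3-trifluoropropyl arm and the cyclopropyl ring together, and the compounds shown do not separate these changes. Also open, on these data alone, is how a piperidine without the methyl group, or a morpholine, would read at this place on the shared core.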